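Bromo substitution on the ketone-bearing ring in two cores

The source may hold more compounds than are shown below. What is called first, only, known or untested is meant among the compounds shown, and "the series" means these compounds.

Compound 1 `COc1ccc2nc(-c3ccc(N/C=C\C(=O)c4cc(OC)c(OC)c(OC)c4)c(C)c3)sc2c1` and compound 2 `COc1cc(OC)c2sc(-c3ccc(N/C=C\C(=O)c4cc(OC)c(OC)c(OC)c4)cc3)nc2c1` share the same side chain and its ketone-bearing aromatic ring but differ in their cores; the difference between the two cores is not broken down here. In a functional assay on MIA PaCa-2 cells (Homo sapiens) for antiproliferative activity, read by sulforhodamine B assay, with a stated time of 48 h (on this read-out lower numbers stand for stronger inhibition and higher numbers for weaker inhibition), compound 1 gives 10000 nM, and compound 2 gives 26800 nM. Compound 3 `COc1ccc2nc(-c3ccc(N/C=C\C(=O)c4cc(OC)c(OC)c(OC)c4Br)c(C)c3)sc2c1` carries the core of compound 1 with the change (bromo in place of hydrogen on an aromatic carbon). In this assay compound 3 gives 23400 nM, a step of a 2.3-fold higher number from compound 1 to compound 3 (0.37 log units; beyond the scatter). Compound 2 and compound 3 give numbers within the scatter of each other, while compound 2 against compound 1 shows a higher number.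

Compound 4 `COc1cc(OC)c2sc(-c3ccc(N/C=C\C(=O)c4cc(OC)c(OC)c(OC)c4Br)cc3)nc2c1` takes the core of compound 2 and applies (bromo in place of hydrogen on an aromatic carbon), the same change at the same place as in the pair of compound 1 and compound 3. Within the data shown here, only one measured instance of this change exists, so the expectation for compound 4 rests on it alone. Among the measured compounds shown here, for compound 4 the expected step of a 2.2-fold higher number from compound 2 to compound 4 (0.34 log units; beyond the scatter) should be of similar size to the earlier one, because the only measured instance of this change is a 2.3-fold higher number from compound 1 to compound 3 (0.37 log units; beyond the scatter). Compound 4 is therefore estimated at 58000 nM in this assay, with a range from 25000 nM to 130000 nM. Since compound 2 already gives a high number, it is possible that compound 4 returns only a limit rather than a number.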

Compound 4, half-maximal inhibitory concentration: 19000 nM
For compound 4 the middle estimate is 3.1-fold (0.48 log units) above the measured one; the measured number lies below the stated range.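

In this assay, among these compounds, bromo in place of hydrogen on an aromatic carbon of the core of compound 2 gives a 1.4-fold lower number from compound 2 to compound 4 (0.15 log units; within the scatter), so on this core the change produces no step that can be told apart from the usual scatter. The change therefore does not carry over at a constant size from one core to the other: the same change on two cores in this assay, a 2.3-fold higher number (0.37 log units; beyond the scatter) from compound 1 to compound 3 and a 1.4-fold lower number (0.15 log units; within the scatter) from compound 2 to compound 4, 3.3-fold (0.52 log units) apart, beyond the scatter of two such steps. This shows only that, for these two pairs, a step measured on one core did not hold on the other; with a single pair per core, it does not show which part of the cores matters, or how the change would behave on any further core.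

The compounds shown leave open whether chloro, an amine or a carboxylic acid in place of the same hydrogen would differ between the two cores as bromo does. Among the compounds shown here, they also leave open which of the structural differences between the core of compound 1 and the core of compound 2 goes with the differing steps, as no compound here separates those differences one at a time.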